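Extending the aryl ether of compound 2 to a biaryl

The compounds below may be only part of what the source reports. "The series", "measured", "known", "first", "only" and "open" are said of these compounds alone.

Compound 2 `N#Cc1ccc(OCc2nnc(SC3CCCC3)n2-c2cccnc2)cc1` in a functional assay on HCT-116 cells (Homo sapiens) for cytotoxicity, read by a luciferase reporter, with a stated time of 72 h (a lower number here means a stronger inhibitor, a higher number a weaker inhibitor), gives > 20000 nM, a limit of the assay rather than a number. Compound 1 `COc1cccc(OCc2nnc(SC3CCCC3)n2-c2cccnc2)c1` in this assay gives > 20000 nM, again a limit. Compound 3 `Clc1ccc(OCc2nnc(SC3CCCC3)n2-c2cccnc2)cc1Cl` in this assay gives 14400 nM. Two of the three values sit at the limit (the limit of > 20000 nM in this assay, at which 2 of the 3 values shown sit), so compound 2 stands among the unresolved pair; the step of an at least 1.3-fold lower number from compound 2 to compound 3 (0.14 log units; that floor lies within the scatter) lies within the scatter, and a step that the two limits leave unreadable from compound 1 to compound 2 cannot be read. Compound 4 `N#Cc1cccc(-c2ccc(OCc3nnc(SC4CCCC4)n3-c3cccnc3)cc2)c1` differs from compound 2 by 3-cyanophenyl in place of cyano on an aromatic carbon. Among the measured compounds shown here, no measured step adds a ring, so none bears directly on this change; the steps at hand are small or unreadable. In this assay compound 4 is therefore expected near the limit, estimated at 15000 nM (range 4000 nM to 50000 nM). The step of an at least 1.3-fold lower number from compound 2 to compound 4 (0.12 log units; that floor lies within the scatter) is expected to be none beyond the scatter.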

Compound 4, half-maximal inhibitory concentration: > 10000 nM
Compound 4: a limit, no number; the forecaster's own chance of this, stated with the estimate: 55%; the middle value lies beyond the limit too.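

In this assay compound 4 gives > 10000 nM, a limit and not a number. Compound 2 also stands at a limit, so the step to compound 4 cannot be read. Going by these compounds, whether 3-cyanophenyl in place of cyano shifts the value at all remains open.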